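From Dichlorobenzyl to Dimethoxybenzyl on a Sulfonamide Diamine

A few compounds are considered here, and "the series" means these few. Any claim that something is new, unique, unknown or untested is made for them only; others in the source may bear on it.

Going by the values given here, compound 3 `O=S(=O)(NCCCNCc1ccc(Cl)c(Cl)c1)c1cc(C(F)(F)F)cc(C(F)(F)F)c1` holds the lowest of the three numbers so far in a functional assay on A2780 cells (Homo sapiens) for inhibition, read by MTT assay, with a stated time of 72 h (a lower number here means a stronger inhibitor of growth, a higher number a weaker inhibitor of growth), namely 1500 nM. Its nearest neighbour is compound 2 `CC(C)(C)c1ccc(CNCCCNS(=O)(=O)c2cc(C(F)(F)F)cc(C(F)(F)F)c2)cc1`, which in this assay gives 2900 nM; the step is a 1.9-fold lower number from compound 2 to compound 3 (0.29 log units; within the scatter), so the two stand together. The furthest is compound 1 `O=S(=O)(NCCCNCc1ccccc1Cl)c1cc(C(F)(F)F)cc(C(F)(F)F)c1`, which in this assay gives 9300 nM; that step is a 6.2-fold lower number from compound 1 to compound 3 (0.79 log units; beyond the scatter). Compound 4 `COc1ccc(CNCCCNS(=O)(=O)c2cc(C(F)(F)F)cc(C(F)(F)F)c2)cc1OC` differs from compound 3 in one place: 3,4-dimethoxyphenyl in place of 3,4-dichlorophenyl on a saturated chain carbon bound to an amine nitrogen. Among the compounds with values here, no measured step exchanges chlorine for a methoxy group, so the evidence is indirect: the benzyl variants so far span a 3.2-fold lower number from compound 1 to compound 2 (0.51 log units; beyond the scatter) and a 6.2-fold lower number from compound 1 to compound 3 (0.79 log units; beyond the scatter), with the dichloro pattern at the low end. The move to the dimethoxy pattern is therefore expected to point toward higher numbers, by a 3.3-fold higher number from compound 3 to compound 4 (0.52 log units; beyond the scatter), though a step within the scatter cannot be excluded. Compound 4 is estimated at 5000 nM in this assay, with a range from 1500 nM to 16000 nM.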

Compound 4, concentration for 50% growth inhibition: 3800 nM
For compound 4 the middle estimate is 1.3-fold (0.12 log units) above the measured one, and the stated range covers the measured number.
By their numbers in this assay, from the lowest: compounds 3, 2 and 4 (each within the scatter of the next, the first and the last beyond it); then compound 1.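

In this assay, the new result shows that this position, on a saturated chain carbon bound to an amine nitrogen, also accepts a group carrying hydrogen-bond acceptors, although the exchange of 3,4-dichlorophenyl for 3,4-dimethoxyphenyl gives a 2.5-fold higher number from compound 3 to compound 4 (0.40 log units; beyond the scatter). The dimethoxy group stands together with 4-(tert-butyl)phenyl, with a 1.3-fold higher number from compound 2 to compound 4 (0.12 log units; within the scatter), and it still compares well with 2-chlorophenyl, with a 2.4-fold lower number from compound 1 to compound 4 (0.39 log units; beyond the scatter), so compound 1 keeps the highest number of the four. No measurement at hand explains how these groups come to be ranked as they are.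

The compounds shown leave open whether a 3,4-difluorophenyl group would stand with compound 3 or with compound 4. They also leave open how a longer chain on the amine nitrogen would change these numbers.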